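This account rests on a few compounds, and the source may have more. Where it says the series, first, only, none or still open, it means among the compounds named here.

In an ADME assay on a cell-free system (plasma, Homo sapiens) for metabolic stability, read by LC-MS, tested at 3 uM (a lower number here means that the compound disappears faster, a higher number that the compound lasts longer), compound 1 `C[C@@H](NC(=O)c1nc(-c2cc(C(F)(F)F)ccn2)nc(O)c1O)C1CCCCC1` gives > 1 h as a limit of the assay, not a number. Compound 2 `COc1ccnc(-c2nc(O)c(O)c(C(=O)N[C@H](C)C3CCCCC3)n2)c1` gives > 6 h as a limit too, so its standing in the series is known only as a limit. Compound 3 `C[C@@H](NC(=O)c1nc(-c2cc(Cl)ccn2)nc(O)c1O)C1CCCCC1` differs from compound 2 by chloro in place of methoxy on an aromatic carbon, the change from 4-methoxypyridin-2-yl to 4-chloropyridin-2-yl chloro in place of methoxy on an aromatic carbon with the rest of the structure unchanged. Among the compounds with values here, the only measured step bearing on this change is a step that the two limits leave unreadable from compound 1 to compound 2 with methoxy in place of trifluoromethyl on an aromatic carbon. Both ends of that step are limits, so it offers neither a size nor a direction to carry over. No step beyond the usual scatter is therefore expected in this assay and no direction can be stated. The expected step is a number no higher from compound 2 to compound 3 (the limit leaves the size open) as an estimate only. Compound 3 is estimated at 6 h with an expected range from 2 h to 15 h and the assay may well report only a limit again.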

Compound 3, half-life: > 6 h
Compound 3: no number, only a limit (the forecaster's own chance of this, stated with the estimate: 65%); the middle value lies on the limit itself.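

In this assay, compound 1, compound 2 and compound 3 are all reported only as limits of the assay, so no step among them can be read: the limit of > 6 h in this assay, at which 2 of the 3 values shown sit.

The compounds shown leave open the actual half-life of each compound, and whether trifluoromethyl, methoxy and chloro differ at all in this assay.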